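Second hydroxy on the pendant aromatic ring of compound 3

The source may hold more compounds than are shown below. What is called first, only, known or untested is meant among the compounds shown, and "the series" means these compounds.

Compound 1 `COc1cccc2cc(-c3ccc([N+](=O)[O-])cc3)c(=O)oc12` gives 8020 nM in an assay on CHO cells for displacement of a labelled ligand from adenosine receptor A3 (Homo sapiens), read by radioligand binding; on this read-out higher numbers stand for weaker inhibition and lower numbers for stronger inhibition. Compound 2 `O=c1oc2c(O)c(O)ccc2cc1-c1ccccc1` gives 3850 nM in this assay, and compound 3 `O=c1oc2c(O)c(O)ccc2cc1-c1ccc(O)cc1` gives 9160 nM, the highest of the three numbers, though its gap to compound 1 lies within the scatter and only its gap to compound 2 lies beyond it. Within the data shown here, the one measured step that bears on the next change is a 2.4-fold higher number from compound 2 to compound 3 (0.38 log units; beyond the scatter), a hydroxy in place of hydrogen on an aromatic carbon. Compound 4 `O=c1oc2c(O)c(O)ccc2cc1-c1ccc(O)c(O)c1` repeats that kind of change: hydroxy in place of hydrogen on an aromatic carbon. On the weight of that single step, a modest rise or no step beyond the scatter is expected in this assay, so the estimated step is a 1.4-fold higher number from compound 3 to compound 4 (0.15 log units; within the scatter). Compound 4 is therefore expected at 13000 nM, within 6000 nM to 28000 nM.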

Compound 4, inhibition constant: 8500 nM
Beside the measured number, compound 4's estimate is 1.5-fold (0.18 log units) above it, and the stated range covers the measured number.
By their numbers in this assay, from the lowest: compound 2; then compounds 1, 4 and 3 (each within the scatter of the next).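

Hydroxy in place of hydrogen on an aromatic carbon, ortho to a hydroxy group, gives a 1.1-fold lower number from compound 3 to compound 4 (0.03 log units; within the scatter) in this assay, so compound 3 and compound 4 cannot be told apart on this read-out. The same kind of change gave a 2.4-fold higher number from compound 2 to compound 3 (0.38 log units; beyond the scatter) at the earlier position, so a step beyond the scatter there does not carry over to this position. No evidence on hand bears on this result. Open, from the compounds shown here alone, is whether methoxy or an amine at this position would separate from compound 3, and whether this hydroxy alone, without the neighbouring one, would give a step beyond the scatter from compound 2.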